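The compounds below may be only part of what the source reports. "The series", "measured", "known", "first", "only" and "open" are said of these compounds alone.

Compound 1 `Nc1sc(-c2ccc(Cl)cc2)c(-c2ccc(Cl)cc2)c1C(=O)NC1CCC1` gives 24800 nM in a functional assay on PC-3 cells (Homo sapiens) for inhibition, read by sulforhodamine B assay, with a stated time of 72 h (on this read-out higher numbers stand for weaker inhibition and lower numbers for stronger inhibition), and stands as the higher of the two numbers recorded so far. Its nearest neighbour, compound 2 `Nc1sc(-c2ccc(Cl)cc2)c(-c2ccc(Cl)cc2)c1C(=O)N1CCC(=O)CC1=O`, gives 9230 nM in this assay, a step of a 2.7-fold lower number from compound 1 to compound 2 (0.43 log units; beyond the scatter) that alters the amide itself rather than the group on its nitrogen. Compound 3 `COc1ccc(CNC(=O)c2c(N)sc(-c3ccc(Cl)cc3)c2-c2ccc(Cl)cc2)cc1` differs from compound 1 by 4-methoxybenzyl in place of cyclobutyl on an amide-type nitrogen. For the measured compounds named here, no measured step bears on this change, so in this assay no shift beyond the scatter is expected, with the step estimated at a 1.4-fold lower number from compound 1 to compound 3 (0.14 log units; within the scatter). Compound 3 is therefore expected near 18000 nM, within 7000 nM to 45000 nM.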

Compound 3, half-maximal inhibitory concentration: 29500 nM
For compound 3 the middle estimate is 1.6-fold (0.21 log units) below the measured one, and the stated range covers the measured number.
By their numbers in this assay, from the lowest: compound 2; then compounds 1 and 3 (each within the scatter of the next).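

On the amide-type nitrogen, 4-methoxybenzyl in place of cyclobutyl brings no shift beyond the scatter in this assay (a 1.2-fold higher number from compound 1 to compound 3 (0.08 log units; within the scatter)), so this position tolerates an aromatic ring as well as a small carbon ring without a change in the number. (4-Methoxybenzyl)amino in place of 2,4-dioxopiperidin-1-yl gives a modest step (a 3.2-fold higher number from compound 2 to compound 3 (0.50 log units; beyond the scatter)), leaving compound 2 alone apart from the other two compounds. Nothing on hand accounts for these numbers.

Open, as far as these compounds go, is whether a carboxylic acid or an amine at the end of a longer chain on this nitrogen would move the number beyond the scatter.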